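Fluoro for chloro on the aryl of compound 1

The source may report more compounds than this note shows. Statements on the series, on what has been measured and on what is new or still open speak of the compounds shown alone.

Three compounds of one series have been run in a functional assay on MCF7 cells (Homo sapiens) for cytotoxicity, read by MTT assay, with a stated time of 4 days; a higher number here means a weaker inhibitor, a lower number a stronger inhibitor. Compound 1, `C=C1C[C@]23C[C@@]1(O)CC[C@H]2c1ccc(OS(=O)(=O)c2ccc(C)cc2)c(C)c1[C@@H]3Cn1cc(-c2ccc(Cl)cc2)nn1`, gives > 20000 nM in this assay; that is a limit of the assay, not a number. Compound 2, `Cc1ccc(S(=O)(=O)Oc2ccc3c(c2C)[C@H](Cn2cc(-c4ccccc4)nn2)[C@@]24CC(=O)[C@@](C)(CC[C@@H]32)C4)cc1`, also returns only a limit, > 20000 nM. Compound 3, `C=C1C[C@]23C[C@@]1(O)CC[C@@H]2c1cccc(C)c1[C@@H]3Cn1cc(-c2ccc(OC)cc2)nn1`, likewise returns only a limit, > 20000 nM. Going by the values given here, every value so far sits at the limit of > 20000 nM in this assay, at which 3 of the 3 values shown sit, so no step between measured compounds can be sized, and compound 1 stands nowhere apart from the other two: all three are reported alike, without a number.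

Compound 4, `C=C1C[C@]23C[C@@]1(O)CC[C@H]2c1ccc(OS(=O)(=O)c2ccc(C)cc2)c(C)c1[C@@H]3Cn1cc(-c2ccc(F)cc2)nn1`, differs from compound 1 in one place: fluoro in place of chloro on an aromatic carbon. In the words of the count, fluoro in place of chloro on an aromatic carbon, para to a large group, so that 4-chlorophenyl becomes 4-fluorophenyl.

Among the compounds with values here, no step of this kind has been measured here, and nothing among compounds 1, 2 and 3 sets this exchange apart, so the expectation is a step of no size beyond the scatter, most likely again a limit rather than a number. The estimated step is a step that the limit leaves unreadable from compound 1 to compound 4. Compound 4 is therefore expected to give about 30000 nM, within 12000 nM to 100000 nM, with a high chance that this assay again reports only a limit.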

Compound 4, half-maximal inhibitory concentration: > 20000 nM
Compound 4: only a limit was reported; the forecaster's own chance of this, stated with the estimate: 85%; the middle value lies beyond the limit too.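

In this assay compound 4 gives > 20000 nM, which is a limit and not a number. No step from compound 1 to compound 4 can be read: the limit of > 20000 nM in this assay, at which 4 of the 4 values shown sit.

The compounds shown leave open whether any member of this series reaches a measurable value in this assay, and what size fluoro in place of chloro has there.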